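This account rests on a few compounds, and the source may have more. Where it says the series, first, only, none or still open, it means among the compounds named here.

Measured so far:
Compound 1 `Cc1ccccc1-n1cc(-c2ccccc2NS(=O)(=O)c2c[nH]c(=O)[nH]c2=O)nn1` gives 9570 nM
Compound 2 `Cc1cccc(-n2cc(-c3ccccc3NS(=O)(=O)c3c[nH]c(=O)[nH]c3=O)nn2)c1` gives 3510 nM
Compound 3 `Cc1ccccc1-n1cc(-c2cccc(NS(=O)(=O)c3c[nH]c(=O)[nH]c3=O)c2)nn1` gives 9230 nM

All three numbers come from a functional assay on SGC-7901 cells (Homo sapiens) for antiproliferative activity, read by MTT assay, with a stated time of 24 h; on this read-out higher numbers stand for weaker inhibition and lower numbers for stronger inhibition. Compound 1 and compound 2 share one core and differ in a single place: 3-methylphenyl in place of 2-methylphenyl on an aromatic nitrogen. That change gave a 2.7-fold lower number from compound 1 to compound 2 (0.44 log units; beyond the scatter). Compound 3 carries the same 2-methylphenyl group as compound 1 but on a different core; the difference between the two cores is not broken down here, and the two values of compound 1 and compound 3 lie within the scatter of each other, so nothing can be read from their order.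

Compound 4 `Cc1cccc(-n2cc(-c3cccc(NS(=O)(=O)c4c[nH]c(=O)[nH]c4=O)c3)nn2)c1` is the unmeasured partner of compound 3, related to it by the same change that turns compound 1 into compound 2: 3-methylphenyl in place of 2-methylphenyl on an aromatic nitrogen. Within the data shown here, because compound 1 to compound 2 gave a 2.7-fold lower number from compound 1 to compound 2 (0.44 log units; beyond the scatter), a step of similar size is expected here, with the single earlier example as the only support, so the spread is wide; the step from compound 3 to compound 4 in this assay is estimated as a 2.6-fold lower number from compound 3 to compound 4 (0.41 log units; beyond the scatter). For compound 4 the expected value in this assay is 3600 nM, estimated to lie between 1500 nM and 9000 nM.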

Compound 4, half-maximal inhibitory concentration: 9100 nM
Compound 4: middle estimate off by 2.5-fold (0.40 log units), on the low side; measured number above the stated range.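

In this assay the swap to 3-methylphenyl in place of 2-methylphenyl on the core of compound 3 gave a 1.0-fold lower number from compound 3 to compound 4 (0.01 log units; within the scatter) and so brought none of the gain seen on the core of compound 1. The change therefore did not carry over from one core to the other, and in these two pairs the size of the step depends on the core it is made on: the same change on two cores in this assay, a 2.7-fold lower number (0.44 log units; beyond the scatter) from compound 1 to compound 2 and a 1.0-fold lower number (0.01 log units; within the scatter) from compound 3 to compound 4, 2.7-fold (0.43 log units) apart, beyond the scatter of two such steps. Two pairs do not show why the cores behave differently, and they cannot tell which of the two results a further core would follow.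

The compounds shown carry only methylphenyl groups on the aromatic nitrogen, so it stays open whether a methoxy group, a chlorine atom or an amine on that phenyl ring would respond to the core in the same way. Also open, as far as these compounds go, is how the two cores would compare with a plain phenyl group carrying no methyl at all.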